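This account rests on a few compounds, and the source may have more. Where it says the series, first, only, none or still open, it means among the compounds named here.

Compound 1 `Cc1ccc(-c2csc(NC(=O)COc3ccccc3C)n2)cc1` and compound 3 `Cc1ccccc1OCC(=O)Nc1nc(-c2ccc(Cl)cc2)cs1` share a core and differ by chloro in place of methyl on an aromatic carbon. In a functional assay on MCF7 cells (Homo sapiens) for cytotoxicity, read by MTT assay, with a stated time of 48 h (a higher number here means a weaker inhibitor, a lower number a stronger inhibitor), compound 1 gives 53500 nM and compound 3 gives 62200 nM, a step of a 1.2-fold higher number from compound 1 to compound 3 (0.07 log units; within the scatter). Compound 2 `Cc1ccc(-c2csc(NC(=O)COc3ccc(F)cc3F)n2)cc1` arises from compound 1 by 2,4-difluorophenyl in place of 2-methylphenyl on an oxygen on a saturated carbon, and in this assay compound 2 gives 14500 nM, so the step is a 3.7-fold lower number from compound 1 to compound 2 (0.57 log units; beyond the scatter). Compound 4 `O=C(COc1ccc(F)cc1F)Nc1nc(-c2ccc(Cl)cc2)cs1` is not yet measured; it stands to compound 3 as compound 2 stands to compound 1, with 2,4-difluorophenyl in place of 2-methylphenyl on an oxygen on a saturated carbon, the same change made on the core of compound 3. Compound 4 is therefore expected to give an estimated 17000 nM in this assay, because the earlier step ran a 3.7-fold lower number from compound 1 to compound 2 (0.57 log units; beyond the scatter). That estimate for compound 4 means an expected step of a 3.7-fold lower number from compound 3 to compound 4 (0.56 log units; beyond the scatter). The expected range for compound 4 runs from 7000 nM to 40000 nM.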

Compound 4, half-maximal inhibitory concentration: 25800 nM
Beside the measured number, compound 4's estimate is 1.5-fold (0.18 log units) below it; the range from low to high includes it.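

In this assay, 2,4-difluorophenyl in place of 2-methylphenyl gives a 2.4-fold lower number from compound 3 to compound 4 (0.38 log units; beyond the scatter) on the core of compound 3, and this step matches the one on the core of compound 1: the same change on two cores in this assay, a 3.7-fold lower number (0.57 log units; beyond the scatter) from compound 1 to compound 2 and a 2.4-fold lower number (0.38 log units; beyond the scatter) from compound 3 to compound 4, 1.5-fold (0.18 log units) apart, within the scatter of two such steps. Chloro in place of methyl on an aromatic carbon gives a 1.8-fold higher number from compound 2 to compound 4 (0.25 log units; within the scatter) with 2,4-difluorophenyl present, and this step also matches its earlier counterpart: the same change on two cores in this assay, a 1.2-fold higher number (0.07 log units; within the scatter) from compound 1 to compound 3 and a 1.8-fold higher number (0.25 log units; within the scatter) from compound 2 to compound 4, 1.5-fold (0.18 log units) apart, within the scatter of two such steps. The two changes therefore carry across these four compounds in this one assay, but this does not show that they would carry to any other core, nor does it explain why the numbers move.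

The compounds shown leave open whether the 2,4-difluorophenyl step would hold with an amine or a carboxylic acid in place of the chloro. They also leave open whether it would survive a longer chain between the oxygen and the carbonyl.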